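The compounds below may be only part of what the source reports. "The series", "measured", "known", "first", "only" and "open" are said of these compounds alone.

In an ADME assay on MDBK cells (Bos taurus) for cytotoxicity, read by MTT assay, with a stated time of 96 h (on this read-out lower numbers stand for higher toxicity in this test and higher numbers for lower toxicity in this test), compound 2 `Cn1c(-c2ccc(N)cc2)nc2cc(C(F)(F)F)ccc21` gives 74000 nM, and compound 1 `CCN(CC)CC(=O)Nc1ccc(-c2nc3cc(C(F)(F)F)ccc3n2C)cc1` gives 57000 nM; the step of a 1.3-fold higher number from compound 1 to compound 2 (0.11 log units; within the scatter) lies within the scatter, so the two numbers cannot be told apart, and compound 2 is simply one of two near-equal results. Compound 3 `Cn1c(-c2ccc(NC(=O)CN3CCCCC3)cc2)nc2cc(C(F)(F)F)ccc21` carries ((piperidin-1-yl)methyl)carbonyl in place of hydrogen on a nitrogen on an aromatic ring. Among the compounds with values here, the one step that bears on this, a 1.3-fold higher number from compound 1 to compound 2 (0.11 log units; within the scatter), removed a closely related group at the same place and barely moved the number, so no change beyond the scatter is expected. Compound 3 is expected to give 62000 nM, with a range from 30000 nM to 130000 nM. The expected step is a 1.2-fold lower number from compound 2 to compound 3 (0.08 log units; within the scatter).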

Compound 3, half-maximal cytotoxic concentration: 100000 nM
Compound 3: middle estimate off by 1.6-fold (0.21 log units), on the low side, and the stated range covers the measured number.
By their numbers in this assay, from the lowest: compounds 1, 2 and 3 (each within the scatter of the next).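

Placing ((piperidin-1-yl)methyl)carbonyl on the aromatic amine nitrogen gives a 1.4-fold higher number from compound 2 to compound 3 (0.13 log units; within the scatter) in this assay and so leaves the number indistinguishable from that of the free amino compound. Replacing diethylamino with piperidin-1-yl on the saturated chain carbon gives a 1.8-fold higher number from compound 1 to compound 3 (0.24 log units; within the scatter) and likewise shows no readable change, so this six-membered ring and the open diethylamino group cannot be told apart here. No measurement is available to explain these results.
As far as these compounds go, whether a morpholine ring, a carboxylic acid or a longer chain at this nitrogen would move the number beyond the scatter remains open.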